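Tert-butyl for hydroxy on the benzylic ring of compound 1

The compounds below may be only part of what the source reports. "The series", "measured", "known", "first", "only" and "open" are said of these compounds alone.

Compound 1 `CN1CCC[C@@H]1Cn1nc(Cc2ccc(O)cc2)c2ccccc2c1=O` gives 251 nM in an assay for binding affinity to Alpha-1A adrenergic receptor (Homo sapiens) (on this read-out lower numbers stand for stronger inhibition and higher numbers for weaker inhibition), the highest of the two numbers in the set; compound 3 `CN1CCC[C@@H]1Cn1nc(Cc2ccc(F)c(F)c2)c2ccccc2c1=O` gives 200 nM, and the step of a 1.3-fold lower number from compound 1 to compound 3 (0.10 log units; within the scatter) lies within the scatter. Compound 2 `CN1CCC[C@@H]1Cn1nc(CC2CCCCC2)c2ccccc2c1=O` reaches only a limit of the assay, > 1990 nM, not a number (the limit of > 1990 nM in this assay, at which 1 of the 3 values shown sits); the steps of an at least 7.9-fold higher number from compound 1 to compound 2 (0.89 log units; beyond the scatter) and an at least 9.9-fold lower number from compound 2 to compound 3 (0.99 log units; beyond the scatter) are therefore both lower bounds.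

Compound 4 `CN1CCC[C@@H]1Cn1nc(Cc2ccc(C(C)(C)C)cc2)c2ccccc2c1=O` differs from compound 1 by tert-butyl in place of hydroxy on an aromatic carbon. Within the data shown here, no measured step exchanges a substituent on the aromatic ring for another carbon group; the nearest is the within-scatter exchange of substituents from compound 1 to compound 3, while the large steps involve losing the aromatic ring altogether, which compound 4 keeps. For compound 4 an inhibition constant of 300 nM is expected in this assay, between 100 nM and 1000 nM. This corresponds to an expected step of a 1.2-fold higher number from compound 1 to compound 4 (0.08 log units; within the scatter), likely within the scatter.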

Compound 4, inhibition constant: > 1990 nM
Compound 4: only a limit was reported (the forecaster's own chance of this, stated with the estimate: 15%); middle value at least 6.6-fold (0.82 log units) from the limit.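

Keeping the aromatic ring is not enough to hold the read-out in this assay: the exchange of hydroxy for tert-butyl alone gives an at least 7.9-fold higher number from compound 1 to compound 4 (0.89 log units; beyond the scatter), a loss that earlier appeared only when cyclohexyl replaced the whole aromatic ring. This aromatic carbon is therefore not indifferent to its substituent, even though the exchange to 3,4-difluorophenyl gave only a 1.3-fold lower number from compound 1 to compound 3 (0.10 log units; within the scatter). Compound 4 stands at a limit of the assay, not at a number: the limit of > 1990 nM in this assay, at which 2 of the 4 values shown sit.

On these data alone, the full size of the step remains unknown, and compound 2 and compound 4 cannot be ranked against each other, since both are limits. As far as these compounds go, whether methyl, methoxy or an amine on this aromatic carbon stays close to compound 1 or also reaches the limit remains open.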